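A Chloro Step from Compound 3

The compounds below may be only part of what the source reports. "The series", "measured", "known", "first", "only" and "open" are said of these compounds alone.

Of the compounds shown here, three with a nitrile on a shared core have been measured. In a physicochemical assay for lipophilicity, measured as octanol-water partition (on this read-out lower numbers stand for lower lipophilicity and higher numbers for higher lipophilicity), compound 1 `N#Cc1c(-c2ccco2)[n+]([O-])c2ccccc2[n+]1[O-]` gives 0.582, compound 2 `N#Cc1c(-c2ccco2)[n+]([O-])c2ccc(C(F)(F)F)cc2[n+]1[O-]` gives 1.5, and compound 3 `Cc1ccc(-c2c(C#N)[n+]([O-])c3ccccc3[n+]2[O-])cc1` gives 2.09, the highest of the three. Compound 4 `Cc1ccc(-c2c(C#N)[n+]([O-])c3cc(Cl)ccc3[n+]2[O-])cc1` is compound 3 with chloro in place of hydrogen on an aromatic carbon. The closest measured change puts trifluoromethyl in place of hydrogen on an aromatic carbon, and it gave a number 0.92 log units higher from compound 1 to compound 2 (beyond the scatter). The swap of furan-2-yl for 4-methylphenyl gave a number 1.51 log units higher from compound 1 to compound 3 (beyond the scatter), but it is a different kind of change. Chloro itself has not been measured here, so a rise somewhat smaller than the trifluoromethyl step is expected, which makes the expected step of a number 0.61 log units higher from compound 3 to compound 4 (beyond the scatter). For compound 4 the estimated value is 2.7, with a range from 2.3 to 3.2.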

Compound 4, partition coefficient: 2.6
For compound 4 the middle estimate is 0.10 log units above the measured one, and the stated range covers the measured number.
By their numbers in this assay, from the lowest: compound 1; then compound 2; then compound 3; then compound 4.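

Chloro in place of hydrogen on an aromatic carbon gives, in this assay, a number 0.51 log units higher from compound 3 to compound 4 (beyond the scatter). Among these compounds, until now, a substituent in place of hydrogen on this six-membered ring had been seen only with furan-2-yl on the shared core; this step shows that a single chlorine can move the number beyond the scatter with 4-methylphenyl there instead. No supporting evidence here explains the rise.

On these data alone, whether chloro gives a similar step with furan-2-yl on the core remains open. So does what an amine or a carboxylic acid would do at this place.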